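A Heteroaryl Swap Expected to Leave Inhibition Unchanged

This account rests on a few compounds, and the source may have more. Where it says the series, first, only, none or still open, it means among the compounds named here.

Measured in an ADME assay on MCF-10A cells (Homo sapiens) for inhibition, read by MTT assay, with a stated time of 48 h, tested at 2 uM; on this read-out lower numbers stand for less inhibition and higher numbers for more inhibition at the one concentration tested (going by the name of the read-out):
Compound 1 `Cc1noc(C)c1-c1ccc2c(c1)C(c1ccccc1)NC(=O)N2C` gives 6.8%.
Compound 2 `Cc1noc(C)c1-c1ccc2c(c1)C(c1ccccc1)N(Cc1nnc(-c3ccccc3)s1)C(=O)N2C` gives 3.3%.
Compound 3 `Cc1noc(C)c1-c1ccc2c(c1)C(c1ccccc1)N(Cc1nc(-c3ccccc3)cs1)C(=O)N2C` gives 2.7%.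

Compound 3 has the lowest of the three numbers, but its gaps to compound 2 and to compound 1 both lie within the scatter, so no ordering can be read from them. Compound 4 `Cc1noc(C)c1-c1ccc2c(c1)C(c1ccccc1)N(Cc1nnc(-c3ccc(F)cc3)o1)C(=O)N2C` differs from it in one place: 5-(4-fluorophenyl)-1,3,4-oxadiazol-2-yl in place of 4-phenyl-1,3-thiazol-2-yl on a saturated chain carbon bound to an amide-type nitrogen in a ring. The step that bears most directly on this change is the earlier exchange of one heteroaryl for another at the same place, a number 0.6 percentage points lower from compound 2 to compound 3 (within the scatter), and the steps of a number 3.5 percentage points lower from compound 1 to compound 2 (within the scatter) and a number 4.1 percentage points lower from compound 1 to compound 3 (within the scatter) likewise stayed within the scatter. A step of no more than the scatter is therefore expected, a number 1.3 percentage points higher from compound 3 to compound 4 (within the scatter). Compound 4 is estimated at 4%, between 0% and 12%.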

Compound 4, a percentage reported as inhibition, at one concentration (the size of the read-out at that concentration, not a potency): 0.7%
Compound 4: the middle estimate sits 3.3 percentage points above what was measured; the measured number falls inside the stated range.
By their numbers in this assay, from the lowest: compounds 4, 3, 2 and 1 (each within the scatter of the next).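

In this assay, the 5-(4-fluorophenyl)-1,3,4-oxadiazol-2-yl group gives no readable shift against either sulfur-containing group at this place (a number 2 percentage points lower from compound 3 to compound 4 (within the scatter); a number 2.6 percentage points lower from compound 2 to compound 4 (within the scatter)). So a ring with oxygen in place of sulfur, carrying a fluorine on its phenyl ring, also stays within the scatter. No measurement here offers an explanation for this result.

Going by these compounds, the ring and the fluorine change together in both steps, so their separate contributions remain open. Also open, on these data alone, is whether an amine or a carboxylic acid in place of the heteroaryl group would give a step beyond the scatter.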